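A few compounds are considered here, and "the series" means these few. Any claim that something is new, unique, unknown or untested is made for them only; others in the source may bear on it.

Among the measured compounds shown here, in an ADME assay on BHK-21 cells (Mesocricetus auratus) for cytotoxicity, read by MTT assay, with a stated time of 96 h (on this read-out lower numbers stand for higher toxicity in this test and higher numbers for lower toxicity in this test), compound 1 `Fc1ccc(F)c(/N=N/c2ccc(NC[C@@H]3CCCN4CCCC[C@H]34)c3c2CCCC3)c1` gives 38000 nM, which is the only true number available so far. Compound 2 `Cc1ccc(/N=N/c2ccc(NCCCN(C)C)cc2)cc1` reads > 100000 nM, and this is a limit of the assay, not a number. For the measured compounds named here, no two measured compounds differ in just one place, so there is no measured step to use as a guide.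

Compound 3 `FC(F)(F)c1cccc(/N=N/c2ccc(NC[C@@H]3CCCN4CCCC[C@H]34)c3c2CCCC3)c1` has not yet been measured. It keeps the core of compound 1 and swaps a single group, with 3-(trifluoromethyl)phenyl in place of 2,5-difluorophenyl on a double-bonded nitrogen. Both groups are phenyl rings carrying fluorine, and the number of heavy atoms changes only slightly. The expectation in this assay is therefore no shift beyond the usual scatter of repeated measurements, and no firm direction. The estimated step, a 1.2-fold lower number from compound 1 to compound 3 (0.07 log units; within the scatter), reflects this expectation. The reasoning rests on a single anchor, compound 1 at 38000 nM, so the range is kept wide. The estimate for compound 3 is 32000 nM, with the measurement expected to fall between 13000 nM and 75000 nM.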

Compound 3, half-maximal cytotoxic concentration: 14000 nM
Compound 3: the middle estimate sits 2.3-fold (0.36 log units) above what was measured; the range from low to high includes it.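

Among the compounds shown here, putting 3-(trifluoromethyl)phenyl in place of 2,5-difluorophenyl on a double-bonded nitrogen gives the first step that can be read from one change in this assay: a 2.7-fold lower number from compound 1 to compound 3 (0.43 log units; beyond the scatter). On this read-out a lower number stands for higher toxicity in the test, so this site on the core of compound 1 is not indifferent to which fluorine-bearing phenyl ring it carries, even though the step is modest and rests on a single pair. Compound 2 stays a limit of the assay and not a number, so it offers no second step to set beside this one: the limit of > 100000 nM in this assay, at which 1 of the 3 values shown sits.

From the compounds shown here alone, with one pair, it remains open whether the shift goes with the trifluoromethyl group that enters or with the fluorines that leave, and the data give no cause for it. Going by these compounds, how a phenyl ring carrying a nitrile or a methoxy group on the same nitrogen would read on this core also remains open, and such compounds could show whether the shift extends beyond these two groups.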